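The source may hold more compounds than are shown below. What is called first, only, known or untested is meant among the compounds shown, and "the series" means these compounds.

Measured so far in a functional assay on HepG2 cells (Homo sapiens) for cytotoxicity, read by MTT assay, with a stated time of 72 h; on this read-out higher numbers stand for weaker inhibition and lower numbers for stronger inhibition:
compound 1 `O=C1C=CCC/C1=C\C=C\c1ccccc1` gives 7100 nM
compound 2 `Cc1ccc(/C=C/C=C2\CCC=CC2=O)cc1` gives 8600 nM
compound 3 `O=C1C=CCC/C1=C\C=C\c1ccc([N+](=O)[O-])cc1` gives 4900 nM

Compound 3 carries the lowest of the three numbers, but it is not separated from the others: the step of a 1.4-fold lower number from compound 1 to compound 3 (0.16 log units; within the scatter) and the step of a 1.8-fold lower number from compound 2 to compound 3 (0.24 log units; within the scatter) both sit inside the scatter, so no ordering among compounds 1, 2 and 3 can be read from these values.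

Compound 4 `CN(C)c1ccc(/C=C/C=C2\CCC=CC2=O)cc1` differs from compound 3 in one place: dimethylamino in place of nitro on an aromatic carbon. Within the data shown here, no measured pair covers this exact exchange. The steps that touch the same position are the change of hydrogen to methyl, a 1.2-fold higher number from compound 1 to compound 2 (0.08 log units; within the scatter), the change of hydrogen to nitro, a 1.4-fold lower number from compound 1 to compound 3 (0.16 log units; within the scatter), and the change of methyl to nitro, a 1.8-fold lower number from compound 2 to compound 3 (0.24 log units; within the scatter); each is within the scatter. Three different groups at this position have left the number where it was, and nothing in the series points to a larger move for dimethylamino. The expectation for the step from compound 3 to compound 4 in this assay is therefore no change beyond the scatter, a 1.2-fold higher number from compound 3 to compound 4 (0.09 log units; within the scatter), with a slightly higher middle to reflect the uncertainty of an untested group. Compound 4 is estimated at 6000 nM, within the range 2500 nM to 15000 nM.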

Compound 4, half-maximal inhibitory concentration: 1100 nM
Beside the measured number, compound 4's estimate is 5.5-fold (0.74 log units) above it, outside the stated range (below it).
By their numbers in this assay, from the lowest: compound 4; then compounds 3, 1 and 2 (each within the scatter of the next).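

In this assay, this place on the aromatic ring proves responsive to substitution, which hydrogen, methyl and nitro had not shown: the steps are a 4.5-fold lower number from compound 3 to compound 4 (0.65 log units; beyond the scatter) and a 7.8-fold lower number from compound 2 to compound 4 (0.89 log units; beyond the scatter) and a 6.5-fold lower number from compound 1 to compound 4 (0.81 log units; beyond the scatter). Dimethylamino is the only one of the four groups to stand apart, while compounds 1, 2 and 3 stay within the scatter of one another, and the exchange of nitro for dimethylamino leaves the count of 3 heavy atoms unchanged, so that count does not mark the difference. Nothing available here accounts for the separation of compound 4 from the others.

On these data alone, whether a smaller amine such as amino or methylamino, an ether such as methoxy, or a ring amine such as morpholine at this place would group with compound 4 or with compounds 1, 2 and 3 remains open. Equally open, as far as these compounds go, is whether the step seen with dimethylamino would persist if the shared core were changed elsewhere.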